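Extending the Chain on a Second Core

This account rests on a few compounds, and the source may have more. Where it says the series, first, only, none or still open, it means among the compounds named here.

Of the compounds shown here, three have been measured so far in a functional assay on cells (Lymphocyte), read by a luciferase reporter and ATP content, with a stated time of 48 h, tested at 10 uM; a higher number here means a weaker effect of the compound at the concentration tested, a lower number a stronger effect. Compound 1, `CCCCCCCCCCc1c(C)c(N(C)C)nc(C)c1O`, gives 40%. Compound 2, `CCCCCCCCCCc1nc(N(C)C)c(C)c(C)c1O`, gives 52%. Compound 3, `CCCCCCCCCCCCCCCCCCCc1c(C)c(N(C)C)nc(C)c1O`, gives 103%.

Compound 3 differs from compound 1 by a single change, (nonyl in place of hydrogen on a saturated chain carbon, ten or more bonds along the chain from an aromatic carbon). That change carried a large step in this assay: a number 63 percentage points higher from compound 1 to compound 3 (beyond the scatter). Compound 2 has the same atoms as compound 1, joined differently; the difference between the two cores is not broken down here. In this assay compound 2 stands above compound 1 and well below compound 3.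

Compound 4, `CCCCCCCCCCCCCCCCCCCc1nc(N(C)C)c(C)c(C)c1O`, has not yet been measured. It differs from compound 2 by nonyl in place of hydrogen on a saturated chain carbon, ten or more bonds along the chain from an aromatic carbon. Among the compounds with values here, this is the same change, at the same place, as the one that separates compound 1 from compound 3. The expectation for compound 4 therefore rests on that one measured step, a number 63 percentage points higher from compound 1 to compound 3 (beyond the scatter), applied to compound 2 as the starting point. Within the data shown here, the step expected from compound 2 to compound 4 in this assay is estimated as a number 48 percentage points higher from compound 2 to compound 4 (beyond the scatter), about as large as the earlier one, with the caution that only one such pair has been seen and that a read-out of this kind rarely rises far past the level compound 3 already shows. For compound 4 the estimate in this assay is 100%, expected to fall between 85% and 115%.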

Compound 4, a percentage reported as activity, at one concentration (the size of the read-out at that concentration, not a potency): 102%
Estimate against measurement, compound 4: 2 percentage points below, and the stated range covers the measured number.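

On the core of compound 2, the same change gives a number 50 percentage points higher from compound 2 to compound 4 (beyond the scatter) in this assay. Set beside the earlier step, the change carries from one core to the other with no difference that can be told apart, in direction or in size: the same change on two cores in this assay, a number 63 percentage points higher (beyond the scatter) from compound 1 to compound 3 and a number 50 percentage points higher (beyond the scatter) from compound 2 to compound 4, 13 percentage points apart, within the scatter of two such steps

This shows only that, in this one read-out at one concentration, nonyl in place of hydrogen at this place on the saturated chain behaves alike on these two cores; it rests on two pairs, and it does not show why the read-out moves, nor that the step would hold on a third core or for any other change at this place.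

The compounds shown leave open how the read-out runs along the chain, since each core appears with only two chain lengths, so a dodecyl or a tetradecyl chain could lie anywhere along that stretch, and the same holds for a hexyl chain on the shorter side. They also leave open whether a chain ending in a carboxylic acid or an amine would give matching steps on the two cores.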